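Nitro in Place of Methyl on the Benzamide of Compound 1

The compounds below may be only part of what the source reports. "The series", "measured", "known", "first", "only" and "open" are said of these compounds alone.

The set rests on two measured compounds. Compound 1 `Cc1ccc(C(=O)Nc2nc3cc(C)cc(C)c3s2)cc1` carries the only numerical result: in a functional assay on NUGC-3 cells (Homo sapiens) for antiproliferative activity, read by sulforhodamine B assay (a lower number here means a stronger inhibitor of growth, a higher number a weaker inhibitor of growth), compound 1 gives 2.37 ug/mL. Compound 2 `COc1ccc2sc(NC(=O)c3ccc(C(F)(F)F)cc3)nc2c1` is known only by a limit of the assay; in this assay compound 2 gives > 10 ug/mL, which is a limit and not a number, the point at which (the limit of > 10 ug/mL in this assay, at which 1 of the 2 values shown sits). For the measured compounds named here, compound 1 therefore stands as the single measured value, the other result sitting at the limit.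

Compound 3 `Cc1cc(C)c2sc(NC(=O)c3ccc([N+](=O)[O-])cc3)nc2c1` has not yet been measured in this assay. It differs from compound 1 in one place: nitro in place of methyl on an aromatic carbon. Going by the values given here, no measured pair in this set separates these two groups, so the step has no precedent here. The step is expected to be a 1.3-fold higher number from compound 1 to compound 3 (0.10 log units; within the scatter), within or close to the scatter. Compound 3 is estimated to give 3 ug/mL in this assay, with a range of 1 ug/mL to 10 ug/mL.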

Compound 3, concentration for 50% growth inhibition: 1.32 ug/mL
For compound 3 the middle estimate is 2.3-fold (0.36 log units) above the measured one, within the range that was stated.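

For the compounds shown here, the step supplies the first measured pair at this position: in this assay, nitro in place of methyl on an aromatic carbon, para to a large group, comes to a 1.8-fold lower number from compound 1 to compound 3 (0.25 log units; within the scatter). Compound 1 and compound 3 therefore read alike in this assay, even though nitro brings 3 heavy atoms where methyl has 1, and hydrogen-bond acceptors where methyl has none. Nothing measured here bears on why these two groups read alike.

A single pair at a single position cannot show whether an amine or a carboxylic acid in the same place would also stay within the scatter of compound 1. It also leaves open whether nitro would read the same way if the methyl groups on the shared core were replaced by other groups.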